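Alkynyloxy coumarin series: chain length step toward compound 3

The source may report more compounds than this note shows. Statements on the series, on what has been measured and on what is new or still open speak of the compounds shown alone.

Measured compounds in an assay on cells for inhibition of Amine oxidase [flavin-containing] B (Homo sapiens), read by Amplex Red, with stated times of 30 min and 45 min; on this read-out lower numbers stand for stronger inhibition and higher numbers for weaker inhibition:
compound 1 `C#CCCCOc1ccc2cc(C(=O)O)c(=O)oc2c1`: > 10000 nM
compound 2 `C#CCCCOc1ccc2c(C)cc(=O)oc2c1`: 18.2 nM

Among the compounds with values here, compound 2 stands as the only compound with a number in this assay. The value of compound 1 is a limit of the assay and not a number, as recorded at the limit of > 10000 nM in this assay, at which 1 of the 2 values shown sits. Within the data shown here, compound 1 and compound 2 differ in more than one place, so their two values show only that compound 2 gives a number where compound 1 gives a limit; no single step can be read from them.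

Compound 3 `C#CCCCCOc1ccc2c(C)cc(=O)oc2c1` has not yet been measured. It differs from compound 2 in one place: propargyl in place of ethynyl on a saturated chain carbon, three bonds along the chain from an oxygen on an aromatic ring. Among the measured compounds shown here, no measured pair in this set spans a change of this kind, so there is no recorded step to lean on.

Compound 3 is expected to give 25 nM, with a range of 7 nM to 90 nM. The step from compound 2 to compound 3 is estimated as a 1.4-fold higher number from compound 2 to compound 3 (0.14 log units; within the scatter), a change not expected to go beyond the scatter.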

Compound 3, half-maximal inhibitory concentration: 0.77 nM
Compound 3: middle estimate off by 32-fold (1.51 log units), on the high side; measured number below the stated range.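

In this assay, within the data shown here, the saturated chain carbon three bonds along the chain from an oxygen on an aromatic ring proves to be a sensitive place: propargyl in place of ethynyl there gives a 24-fold lower number from compound 2 to compound 3 (1.37 log units; beyond the scatter) and is the first step that can be read at a single place. Read along the chain, the same difference is pent-4-yn-1-yl to hex-5-yn-1-yl, so lengthening the chain moves the number well beyond the scatter, while the count of triple bonds and the count of hydrogen-bond donors and acceptors stay the same. Nothing recorded for these compounds gives a reason for the size of this step.

As far as these compounds go, with a single step, it remains open whether a longer chain such as hept-6-yn-1-yl would continue this trend or reverse it, and whether the triple bond matters at all compared with a saturated hexyl chain. From the compounds shown here alone, it is also open how the hex-5-yn-1-yl chain would behave with a carboxylic acid on the shared core, in place of the methyl group of compound 3.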